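A few compounds are considered here, and "the series" means these few. Any claim that something is new, unique, unknown or untested is made for them only; others in the source may bear on it.

Compound 1 `NC(=O)c1c(NC(=O)c2ccccc2Cl)sc2c1CCN(Cc1ccccc1)C2`, compound 2 `NC(=O)c1c(NC(=O)c2ccccc2Cl)sc2c1CCN(Cc1cc(Cl)cc(Cl)c1)C2` and compound 3 `NC(=O)c1c(NC(=O)c2ccccc2Cl)sc2c1CCN(C(=S)Nc1ccccc1)C2` share one core and differ only in the group on the ring amine nitrogen. In a functional assay on MKN-74 cells (Homo sapiens) for antiproliferative activity, with a stated time of 24 h (on this read-out lower numbers stand for stronger inhibition and higher numbers for weaker inhibition), compound 1 gives 14500 nM, compound 2 gives 23700 nM, and compound 3 gives 15600 nM. Compound 3 therefore stands level with the other two: a 1.1-fold higher number from compound 1 to compound 3 (0.03 log units; within the scatter) and a 1.5-fold lower number from compound 2 to compound 3 (0.18 log units; within the scatter), both within the scatter. Compound 4 `NC(=O)c1c(NC(=O)c2ccccc2Cl)sc2c1CCN(C(=S)Nc1ccc(C(F)(F)F)cc1)C2` is built from compound 3 by trifluoromethyl in place of hydrogen on an aromatic carbon. Within the data shown here, the only step that resembles it is a 1.6-fold higher number from compound 1 to compound 2 (0.21 log units; within the scatter), where chlorines entered the pendant ring with no shift beyond the scatter. He therefore expects no step beyond the scatter, a 1.2-fold higher number from compound 3 to compound 4 (0.06 log units; within the scatter), and estimates compound 4 at 18000 nM, between 8000 nM and 40000 nM.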

Compound 4, half-maximal inhibitory concentration: 7090 nM
For compound 4 the middle estimate is 2.5-fold (0.40 log units) above the measured one; the whole stated range lies above it.
By their numbers in this assay, from the lowest: compound 4; then compounds 1, 3 and 2 (each within the scatter of the next).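

On the pendant ring of the thiourea series, trifluoromethyl on an aromatic carbon para to a large group gives a 2.2-fold lower number from compound 3 to compound 4 (0.34 log units; beyond the scatter) in this assay, a modest step, but the first one here beyond the scatter. The chlorines of a 1.6-fold higher number from compound 1 to compound 2 (0.21 log units; within the scatter) stayed within it, so the pendant ring is not silent to every substitution. Nothing available explains the step.

From the compounds shown here alone, whether a methoxy or a nitrile at the same carbon would do the same remains open, as does whether trifluoromethyl would shift compound 1 likewise.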